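A few compounds are considered here, and "the series" means these few. Any claim that something is new, unique, unknown or untested is made for them only; others in the source may bear on it.

Measured in a functional assay on HCT-116 cells (Homo sapiens) for antiproliferative activity, read by MTT assay, with a stated time of 72 h; a higher number here means a weaker inhibitor, a lower number a stronger inhibitor:

- compound 1, `NC1=NC2(CCSCC2)N(OCCCOc2cccc(Cl)c2)C(N)=N1`: 1 nM
- compound 2, `NC1=NC2(CCSCC2)N(OCCCOc2cccc(Cl)c2Cl)C(N)=N1`: 1 nM
- compound 3, `NC1=NC2(CCSCC2)N(OCCCOc2ccccc2Br)C(N)=N1`: 1 nM

All three compounds share the same core and differ only in the group attached through an oxygen on a saturated carbon. On the numbers shown, compound 3 stands level with compounds 1 and 2 in this assay; the three values are indistinguishable within the scatter, so none of them can be called the strongest.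

Compound 4, `NC1=NC2(CCSCC2)N(OCCCOc2cccc(Br)c2)C(N)=N1`, has not yet been measured. It differs from compound 3 by 3-bromophenyl in place of 2-bromophenyl on an oxygen on a saturated carbon.

Among the measured compounds shown here, three measured steps bear on this kind of change, each moving halogens around the aromatic ring at the same place: no change at the digits printed from compound 1 to compound 2 (within the scatter), no change at the digits printed from compound 1 to compound 3 (within the scatter) and no change at the digits printed from compound 2 to compound 3 (within the scatter). None of them produced a shift beyond the scatter. Because no change at the digits printed from compound 1 to compound 3 (within the scatter) and no change at the digits printed from compound 2 to compound 3 (within the scatter) were flat, the expected step of no change at the digits printed from compound 3 to compound 4 (within the scatter) is likewise no change beyond the scatter. Compound 4 is therefore estimated to give 1 nM, with a range from 0.5 nM to 3 nM.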

Compound 4, half-maximal inhibitory concentration: 1 nM
For compound 4 middle estimate and measured number coincide at the digits printed; low and high end bracket the measured number.
By their numbers in this assay, from the lowest: compounds 1, 2, 3 and 4 (each within the scatter of the next).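

In this assay, among the compounds shown here, 3-bromophenyl in place of 2-bromophenyl gives no change at the digits printed from compound 3 to compound 4 (within the scatter), the one step here that moves a single halogen around the ring while keeping that halogen the same. Bromo in place of chloro gives no change at the digits printed from compound 1 to compound 4 (within the scatter), a direct exchange of one halogen for another, while 3-bromophenyl in place of 2,3-dichlorophenyl gives no change at the digits printed from compound 2 to compound 4 (within the scatter), so neither the identity of this halogen nor the loss of a second one registers in these compounds. No supporting measurement is available to explain this flat picture.

All the groups shown at this position are phenyl rings bearing chloro or bromo, so the effect of an amine or a carboxylic acid on that ring remains open. Also open, on these data alone, is whether an unsubstituted phenyl or a longer chain carrying the phenoxy group would keep the same level.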